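The compounds below may be only part of what the source reports. "The series", "measured", "known", "first", "only" and "open" are said of these compounds alone.

Measured compounds:
compound 1 `COc1ccc(CCCCCCCCOc2ccc(C[S+]([O-])c3cccc(C(=O)O)c3)nc2/C=C/C(=O)O)cc1` — 167 nM
compound 2 `COc1ccc(CCCCCCCCOc2ccc(CSCc3cccc(C(=O)O)c3)nc2CCC(=O)O)cc1` — 8 nM

Among the compounds with values here, in an assay on isolated protein for displacement of a labelled ligand from leukotriene B4 receptor 1 (Homo sapiens) (a higher number here means a weaker inhibitor, a lower number a stronger inhibitor), compound 1 gives 167 nM, the higher of the two numbers so far; in this assay compound 2 gives 8 nM, a markedly lower number, and the gap between them lies beyond the usual scatter. Within the data shown here, no single-point step between the two measured compounds exists, as they differ in more than one place, so the two values are read only as they stand.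

The step from compound 1 to compound 3 `COc1ccc(CCCCCCCCOc2ccc(CSCc3ccc(C(=O)O)cc3)nc2/C=C/C(=O)O)cc1` replaces (a group of 11 heavy atoms (8 carbon, 2 oxygen, 1 sulfur; one six-membered aromatic ring of carbon only) in place of a group of 11 heavy atoms (7 carbon, 3 oxygen, 1 sulfur; one six-membered aromatic ring of carbon only), on a saturated chain carbon bound to an aromatic carbon), the entering group being (4-carboxybenzyl)sulfanyl. Among the measured compounds shown here, compound 2 carries a sulfanyl link of the same kind and gives the lower of the two measured numbers, and this is the only guide available; the shift of the carboxylic acid on the outer ring and the unsaturated acid on the shared core of compound 1 are retained without a matched pair. The step is expected to lower the number in this assay by a clear margin, beyond the scatter.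

For compound 3 in this assay the estimate is 20 nM, within 5 nM to 80 nM. This estimate corresponds to an expected step of an 8.4-fold lower number from compound 1 to compound 3 (0.92 log units; beyond the scatter).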

Compound 3, inhibition constant: 5.7 nM
The estimate for compound 3 lay 3.5-fold (0.55 log units) above the measured number; the measured number falls inside the stated range.
By their numbers in this assay, from the lowest: compounds 3 and 2 (each within the scatter of the next); then compound 1.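

In this assay, within the data shown here, the first reading at a single position shows that the site on a saturated chain carbon bound to an aromatic carbon strongly affects the number: with the rest of compound 1 unchanged, installing (4-carboxybenzyl)sulfanyl gives a 29-fold lower number from compound 1 to compound 3 (1.47 log units; beyond the scatter). The leaving and entering groups match in their counts of heavy atoms, hydrogen-bond donors and hydrogen-bond acceptors, so a step of this size arises without any change in those counts, and the difference lies in the composition and arrangement of the group, 7 carbon, 3 oxygen and 1 sulfur giving way to 8 carbon, 2 oxygen and 1 sulfur. No measurement bearing on the origin of this step is available.

The exchange alters the sulfur link and the placement of the carboxylic acid on the outer ring in one move, so the compounds shown do not divide the step among these features. A (4-carboxybenzyl)sulfinyl group on the same core would test the sulfur link alone, while a tetrazole in place of the carboxylic acid on the outer ring would show whether that acid itself is needed at this site.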